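This account rests on a few compounds, and the source may have more. Where it says the series, first, only, none or still open, it means among the compounds named here.

Four compounds of one shared core are considered here, measured for cytotoxicity in a toxicity assay on HepG2 cells (Homo sapiens) for cytotoxicity, read by MTT assay, with a stated time of 72 h; a lower number here means that less compound is tolerated, a higher number that more compound is tolerated. Compound 1 `O=[N+]([O-])c1ccc2nc(Nc3ccccc3)c(Nc3ccccc3)nc2c1` carries no reported result, giving "nd" (no result reported) in this assay. For the measured compounds named here, compound 2 `O=[N+]([O-])c1ccc2nc(NCc3ccccc3)c(NCc3ccccc3)nc2c1` is the only one with a number, and in this assay compound 2 gives 5080 nM. Going by the values given here, compound 3 `Nc1ccc2nc(Nc3ccc(Cl)c(Cl)c3)c(Nc3ccc(Cl)c(Cl)c3)nc2c1` stands without a single number, since in this assay compound 3 reports "nd" (no result reported); this leaves the pair of interest without a measured starting point, and the only anchor is the value of compound 2.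

Compound 4 `CC(=O)Nc1ccc2nc(Nc3ccc(Cl)c(Cl)c3)c(Nc3ccc(Cl)c(Cl)c3)nc2c1` differs from compound 3 by acetyl in place of hydrogen on a nitrogen on an aromatic ring. Among the compounds with values here, no step between measured compounds is available for this change. Given that compound 2 gives 5080 nM in this assay, compound 4 is expected to sit in the same broad region, with any difference from the core series likely to be no larger than the usual scatter, and compound 4 is therefore estimated at 8000 nM, with a range from 2000 nM to 40000 nM.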

Compound 4, half-maximal cytotoxic concentration: 4590 nM
Compound 4: middle estimate off by 1.7-fold (0.24 log units), on the high side; the measured number falls inside the stated range.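

For the compounds shown here, compound 3 gives "nd" (no result reported) in this assay and compound 4 gives 4590 nM here, so no step from amino to acetamido can be read between them. Nothing shown offers an explanation for the value of compound 4. The compounds shown leave open whether acetyl in place of hydrogen on that nitrogen shifts the tolerated concentration at all.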